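A few compounds are considered here, and "the series" means these few. Any claim that something is new, unique, unknown or untested is made for them only; others in the source may bear on it.

Compound 1 `CCCCCC#C[C@@]1(C)O[C@@H]2OC(=O)N(C(=O)CCl)[C@@H]2CC1=O`: 31000 nM
Compound 2 `CCCCCC#C[C@]1(C)O[C@@H]2OC(=O)N(C(=O)CCl)[C@@H]2CC1=O`: 32000 nM
Compound 3 `C[C@]1(C#CCCCCc2ccccc2)O[C@@H]2OC(=O)N(C(=O)CCl)[C@@H]2CC1=O`: 27000 nM

These three compounds were tested in a functional assay on L1210 cells (Mus musculus) for inhibition; on this read-out higher numbers stand for weaker inhibition and lower numbers for stronger inhibition. Compound 1 stands level with the other two, as no gap among them exceeds the scatter. A change of configuration at a saturated ring carbon gives a 1.0-fold higher number from compound 1 to compound 2 (0.01 log units; within the scatter). Phenyl in place of methyl on a saturated chain carbon, four bonds along the chain from a triple-bonded carbon, gives a 1.1-fold lower number from compound 1 to compound 3 (0.06 log units; within the scatter).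

Compound 4 `CCCCC/C=C/[C@@]1(C)O[C@@H]2OC(=O)N(C(=O)CCl)[C@@H]2CC1=O` has not yet been measured. It carries hept-1-en-1-yl in place of hept-1-yn-1-yl on a saturated ring carbon. Neither measured step replaces the triple bond itself, so they bear on this change only indirectly. Both show the number staying put when this part of compound 1 is altered, so no step beyond the scatter is expected. The expected step is a 1.0-fold lower number from compound 1 to compound 4 (0.01 log units; within the scatter), with no firm direction. For compound 4 the estimated value is 30000 nM, with an expected range from 14000 nM to 62000 nM.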

Compound 4, half-maximal inhibitory concentration: 81000 nM
Compound 4: the middle estimate sits 2.7-fold (0.43 log units) below what was measured; the whole stated range lies below it.
By their numbers in this assay, from the lowest: compounds 3, 1 and 2 (each within the scatter of the next); then compound 4.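

In this assay, within the data shown here, hept-1-en-1-yl in place of hept-1-yn-1-yl on a saturated ring carbon gives a 2.6-fold higher number from compound 1 to compound 4 (0.42 log units; beyond the scatter) as a modest step, and it is the only step here that lies beyond the scatter. The number at this position is therefore not indifferent to every change: the change of configuration at the ring carbon and phenyl in place of methyl on the chain both left it level, whereas the double bond in place of the triple bond, with the carbon count unchanged, weakens inhibition. Nothing given here accounts for this step.

On these data alone, whether the other geometry of the double bond, or the opposite ring configuration with it, would give the same number remains open. So does how a saturated heptyl chain or a shorter propyl chain would fare in this place.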